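The source may report more compounds than this note shows. Statements on the series, on what has been measured and on what is new or still open speak of the compounds shown alone.

Measured so far in a functional assay on HepG2 cells (Homo sapiens) for cytotoxicity, with a stated time of 72 h; a lower number here means that less compound is needed, a higher number that more compound is needed for the effect:
Compound 1 `C=C[C@@](C)(/C=C/c1ccc(O)cc1)CCCO`: > 52000 nM, a limit.
Compound 2 `C=C[C@@](C)(/C=C/c1ccc(O)cc1)CC/C=C/C(=O)OCC`: > 52000 nM, a limit.
Compound 3 `C=C[C@@](C)(/C=C/c1ccc(O)cc1)CC/C=C(C)/C=N/N`: > 52000 nM, a limit.

Compound 3 has no number of its own, and its > 52000 nM is a limit. The other measured compounds share that position: the limit of > 52000 nM in this assay, at which 3 of the 3 values shown sit.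

The change to compound 4 `C=C[C@@](C)(/C=C/c1ccc(O)cc1)CC/C=C(\C)C=O` is a group of 2 heavy atoms (1 carbon, 1 oxygen; no ring) in place of a group of 3 heavy atoms (1 carbon, 2 nitrogen; no ring), on a double-bonded chain carbon bound to a double-bonded chain carbon and a saturated chain carbon. Formyl enters on a double-bonded chain carbon bound to a double-bonded chain carbon and a saturated chain carbon.

The measured steps that bear on this change are a step that the two limits leave unreadable from compound 1 to compound 3, a step that the two limits leave unreadable from compound 2 to compound 3 and a step that the two limits leave unreadable from compound 1 to compound 2. None of them gives a size or a direction to carry over. Formyl also has no measured precedent in the series, so the step cannot be sized by analogy.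

The expectation rests on compound 3, whose > 52000 nM is a limit. No clear step in either direction is expected in this assay, and a further limit is the likeliest report, although a number cannot be excluded. The expected step is an at least 1.1-fold lower number from compound 3 to compound 4 (0.06 log units; that floor lies within the scatter).

The estimate for compound 4 is 45000 nM, with an expected range of 15000 nM to 70000 nM.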

Compound 4, half-maximal effective concentration: > 52000 nM
Compound 4 gave a limit, no number; the forecaster's own chance of this, stated with the estimate: 65%; middle value at least 1.1-fold (0.06 log units) away from the limit.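

In this assay compound 4 gives > 52000 nM, a limit and not a number. Within the data shown here, its steps from compound 1, compound 2 and compound 3 cannot be read, so no new step follows from this result. The compounds shown share one position: the limit of > 52000 nM in this assay, at which 4 of the 4 values shown sit.

The compounds shown leave open whether any chain on the shared core gives a readable number in this assay.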